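Lengthening an Ethyl to a Propyl on a Shared Core

The source may report more compounds than this note shows. Statements on the series, on what has been measured and on what is new or still open speak of the compounds shown alone.

Measured so far in a functional assay on MGC-803 cells (Homo sapiens) for inhibition, read by sulforhodamine B assay; on this read-out higher numbers stand for weaker inhibition and lower numbers for stronger inhibition:
compound 1, `CCCc1ccc(NC2=CC(=O)c3c(nc4n3[C@H]3OC[C@@H](O)[C@H]3OC4)C2=O)cc1`: 1920 nM
compound 2, `CCc1ccc(NC2=CC(=O)c3nc4n(c3C2=O)[C@H]2OC[C@@H](O)[C@H]2OC4)cc1`: 1290 nM
compound 3, `O=C1C(Nc2ccccc2)=CC(=O)c2c1nc1n2[C@H]2OC[C@@H](O)[C@H]2OC1`: 1830 nM

Compound 2 gives the smallest of the three numbers, but its gaps to compound 3 and to compound 1 are both within the scatter, so the three compounds cannot be told apart on these data. Compound 4, `CCCc1ccc(NC2=CC(=O)c3nc4n(c3C2=O)[C@H]2OC[C@@H](O)[C@H]2OC4)cc1`, has not yet been measured. It keeps the core of compound 2 and differs from it in one place: methyl in place of hydrogen on a saturated chain carbon, two bonds along the chain from an aromatic carbon.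

For the measured compounds named here, only one measured step speaks to a change of this chain. Removing the whole propyl gave a 1.0-fold lower number from compound 1 to compound 3 (0.02 log units; within the scatter), so going from no chain to a three-carbon chain did not move this assay beyond the scatter. Compound 1, which carries the propyl on a differently arranged core, and compound 2 are also within the scatter of each other. The expected step from compound 2 to compound 4 is therefore a 1.1-fold higher number from compound 2 to compound 4 (0.04 log units; within the scatter), no change beyond the scatter. Compound 4 is estimated at 1400 nM, with a range from 700 nM to 2800 nM.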

Compound 4, half-maximal inhibitory concentration: 1560 nM
For compound 4 the middle estimate is 1.1-fold (0.05 log units) below the measured one, within the range that was stated.
By their numbers in this assay, from the lowest: compounds 2, 4, 3 and 1 (each within the scatter of the next).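

The change from 4-ethylphenyl to 4-propylphenyl gives a 1.2-fold higher number from compound 2 to compound 4 (0.08 log units; within the scatter) in this assay on the shared core of compound 2 and compound 4. For the compounds shown here, the only earlier step bearing on this chain removed the whole propyl group, whereas this one adds a single methyl on a saturated chain carbon, two bonds along the chain from an aromatic carbon, and still leaves the number within the scatter. No measurement shown offers an explanation for this result, so it stands as an observation only.

The compounds shown stop at the propyl group, leaving open how a longer chain such as butyl or hexyl, or a chain ending in an amine or a carboxylic acid, would read at this place. Whether any such group would move the number beyond the scatter cannot be told from these compounds.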